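This account rests on a few compounds, and the source may have more. Where it says the series, first, only, none or still open, it means among the compounds named here.

Compound 2, `CCCOc1ccc(C(=O)Nc2cccc(Cl)n2)cc1`, stands in an in vitro assay on HEK-tsA201 cells for antagonist activity at Neuronal acetylcholine receptor; alpha4/beta2 (Homo sapiens), read by fluorescence and calcium flux (a higher number here means a weaker inhibitor, a lower number a stronger inhibitor), only at a limit of the assay, since compound 2 gives > 100000 nM. Compound 1, `C=CCOc1ccc(C(=O)Nc2cccc(Cl)n2)cc1`, sits at a limit as well: in this assay compound 1 gives > 100000 nM. For the measured compounds named here, the step that the two limits leave unreadable from compound 1 to compound 2 therefore cannot be read, and the only evidence from the measured pair is the limit of > 100000 nM in this assay, at which 2 of the 2 values shown sit. Compound 3, `CCCCCCNc1cccc(NC(=O)c2ccc(OCCC)cc2)n1`, differs from compound 2 by hexylamino in place of chloro on an aromatic carbon. No measured step bears on a change at that aromatic carbon, so nothing shown points to a gain in inhibition, and the step from compound 2 to compound 3 is expected to be a number no higher from compound 2 to compound 3 (the limit leaves the size open), with the real chance that this assay again reports only a limit. For compound 3 the estimated half-maximal inhibitory concentration in this assay is 100000 nM, expected to lie between 20000 nM and 300000 nM.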

Compound 3, half-maximal inhibitory concentration: > 100000 nM
Compound 3 was reported as a limit (the forecaster's own chance of this, stated with the estimate: 70%); the middle value sits exactly at the limit.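

In this assay compound 3 gives > 100000 nM, which is a limit of the assay. Compound 2 also stands at a limit, so the step from compound 2 to compound 3 cannot be read. The compounds shown leave open which change to the shared core, if any, would give a measurable half-maximal inhibitory concentration.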